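The source may hold more compounds than are shown below. What is called first, only, known or untested is meant among the compounds shown, and "the series" means these compounds.

In a physicochemical assay for lipophilicity, measured as octanol-water partition (a higher number here means a more lipophilic compound, a lower number a more polar compound), compound 2 `Cc1cc(Cl)c(OCCCO)c(Cl)c1` gives 3.36. That lies within the usual scatter of compound 1 `Cc1cc(Cl)cc(C)c1OCC(C)O` at 3.52, and clearly higher than compound 3 `Cc1cc(Cl)ccc1OCC(C)O` at 2.84. Compound 4 `Cc1cc(Cl)c(OCC(C)O)c(Cl)c1` holds the same atoms as compound 2, joined differently: 1-hydroxyethyl in place of 2-hydroxyethyl on a saturated chain carbon bound to an oxygen on an aromatic ring. In other words, 3-hydroxypropyl becomes 2-hydroxypropyl. Among the measured compounds shown here, the only measured step, a number 0.68 log units lower from compound 1 to compound 3 (beyond the scatter), comes from hydrogen in place of methyl on an aromatic carbon. For the measured compounds named here, that is a different change, so no measured pair shows this rearrangement directly, and the step offers only a sense of scale. With no atoms gained or lost, the step expected in this assay is small, a number 0.09 log units higher from compound 2 to compound 4 (within the scatter), and no larger than the scatter. For compound 4 the estimated value is 3.45, with an expected range from 3.15 to 3.75.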

Compound 4, partition coefficient: 3.16
Estimate against measurement, compound 4: 0.29 log units above; low and high end bracket the measured number.
By their numbers in this assay, from the lowest: compound 3; then compounds 4, 2 and 1 (each within the scatter of the next, the first and the last beyond it).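

In this assay, among the compounds shown here, replacing 3-hydroxypropyl with 2-hydroxypropyl on the shared core gives a number 0.20 log units lower from compound 2 to compound 4 (within the scatter) and so offers the first direct reading of this rearrangement. With no atoms gained or lost, this change on a saturated chain carbon bound to an oxygen on an aromatic ring does not separate the two isomers in this measurement. No evidence here explains the result. Still open, as far as these compounds go, is how a longer chain, such as 4-hydroxybutyl, or an amine in place of the hydroxy group would read in this assay on this core. Also open, from the compounds shown here alone, is whether the same rearrangement gives a similar step on the core of compound 1.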